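Three inactive compounds and one open question

The compounds below may be only part of what the source reports. "The series", "measured", "known", "first", "only" and "open" are said of these compounds alone.

Compound 1 `O=C1COc2ccc(-c3cccc(NS(=O)(=O)c4ccc(F)cc4)c3)cc2N1` gives > 40000 nM (a limit)
Compound 2 `O=C1COc2ccc(-c3cnc4ccccc4c3)cc2N1C1CCCCC1` gives > 40000 nM (a limit)
Compound 3 `O=C1COc2ccc(-c3cccc(NS(=O)(=O)c4ccc(F)cc4)c3)cc2N1C1CC1` gives > 40000 nM (a limit)

In a functional assay on HepG2 cells (Homo sapiens) for antiproliferative activity, read by MTT assay, with a stated time of 72 h (on this read-out lower numbers stand for stronger inhibition and higher numbers for weaker inhibition), compound 3 stands at > 40000 nM and that is a limit, not a number. The evidence so far is the limit of > 40000 nM in this assay, at which 3 of the 3 values shown sit, and no measured number exists to start from.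

Compound 4 `Cc1ccc(N2C(=O)COc3ccc(-c4cccc(NS(=O)(=O)c5ccc(F)cc5)c4)cc32)cc1` keeps the rest of compound 3 and changes one group. A 4-methylphenyl takes the place of the cyclopropyl on an amide-type nitrogen in a ring 4-methylphenyl in place of cyclopropyl on an amide-type nitrogen in a ring and this is the whole difference.

Within the data shown here, one measured step touches the same nitrogen: a step that the two limits leave unreadable from compound 1 to compound 3 and it therefore offers no size to carry over. The data give no direction for the new group either. With nothing readable behind it, the cautious expectation in this assay is no step beyond the usual scatter, and compound 4 may well be reported as a limit again.

The expected step is an at least 1.1-fold lower number from compound 3 to compound 4 (0.05 log units; that floor lies within the scatter) and it is only an estimate. The estimate for compound 4 is 35000 nM in this assay as a central value. For compound 4 the expected range runs from 10000 nM to 60000 nM in this estimate.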

Compound 4, half-maximal inhibitory concentration: > 40000 nM
Compound 4: a limit, no number (the forecaster's own chance of this, stated with the estimate: 65%); middle value at least 1.1-fold (0.05 log units) away from the limit.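

In this assay compound 4 gives > 40000 nM, which is a limit and not a number. The steps to compound 4 from compound 3 and from compound 1 therefore cannot be read. The compounds shown leave open whether any group on the amide-type nitrogen in a ring can yield a measurable number, for the evidence so far is only this: the limit of > 40000 nM in this assay, at which 4 of the 4 values shown sit.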